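This account rests on a few compounds, and the source may have more. Where it says the series, first, only, none or still open, it means among the compounds named here.

The series shares the core of compound 1 `Cn1cc(-c2cnc3c(-c4csc(C(=O)N[C@@H]5CCC[C@@H]5O)c4)cnn3c2)cn1`, which in an assay for inhibition of MAP/microtubule affinity-regulating kinase 3 (Homo sapiens), read by HTRF, with a stated time of 2 h (a higher number here means a weaker inhibitor, a lower number a stronger inhibitor), gives 43 nM. Compound 2 `CCNC(=O)c1cc(-c2cnn3cc(-c4cnn(C)c4)cnc23)cs1` gives 129 nM, the change being a 3.0-fold higher number from compound 1 to compound 2 (0.48 log units; beyond the scatter). Compound 3 `Cn1cc(-c2cnc3c(-c4csc(C(=O)N[C@@H]5CCCC[C@@H]5N)c4)cnn3c2)cn1` is reported only as a limit of the assay, <= 0.5 nM (the limit of <= 0.5 nM in this assay, at which 1 of the 3 values shown sits). Compound 3 therefore stands at the low edge of the numbers shown, with an at least 86-fold lower number from compound 1 to compound 3 (1.93 log units; beyond the scatter) and an at least 250-fold lower number from compound 2 to compound 3 (2.41 log units; beyond the scatter) both beyond the scatter. Compound 4 `Cn1cc(-c2cnc3c(-c4csc(C(=O)N[C@@H]5CCC[C@H]5O)c4)cnn3c2)cn1` differs from compound 3 as follows: 2-hydroxycyclopentyl in place of 2-aminocyclohexyl on an amide-type nitrogen. The step bearing on this is the reverse of the large one between compound 1 and compound 3, so a large rise in the number is expected, an at least 100-fold higher number from compound 3 to compound 4 (2.00 log units; beyond the scatter). With the same 2-hydroxycyclopentyl as in compound 1, compound 4 is estimated at 50 nM, within 10 nM to 250 nM.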

Compound 4, half-maximal inhibitory concentration: 10 nM
Estimate against measurement, compound 4: 5.0-fold (0.70 log units) above; the range from low to high includes it.
By their numbers in this assay, from the lowest: compound 4; then compound 1; then compound 2. At a limit, below all of these: compound 3.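

The 2-hydroxycyclopentyl group on the amide-type nitrogen responds to its drawn configuration, with a 4.3-fold lower number from compound 1 to compound 4 (0.63 log units; beyond the scatter), and this step reads on configuration alone: the fact that compounds 1 and 4 differ only in the configuration as drawn. With this configuration, the group also stands clear of ethyl, with a 13-fold lower number from compound 2 to compound 4 (1.11 log units; beyond the scatter). It still does not reach 2-aminocyclohexyl, with an at least 20-fold higher number from compound 3 to compound 4 (1.30 log units; beyond the scatter), and the size of this step is only a bound: the limit of <= 0.5 nM in this assay, at which 1 of the 4 values shown sits.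

From the compounds shown here alone, whether the amine or the six-membered ring carries the gain in compound 3 stays open; 2-aminocyclopentyl or 2-hydroxycyclohexyl would separate the two. Going by these compounds, the effect of configuration within 2-aminocyclohexyl also remains open.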